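Solubility at the Limit: From Compound 3 to Compound 4

The source may report more compounds than this note shows. Statements on the series, on what has been measured and on what is new or still open speak of the compounds shown alone.

Measured compounds in a physicochemical assay for solubility, using the shake flask method, in simulated intestinal fluid, measured as kinetic solubility, with a stated time of 2 h, at 25 degrees C, at pH 6.5; on this read-out lower numbers stand for lower solubility and higher numbers for higher solubility:
compound 1 `Cc1noc(-c2nc(C)c3c(c2N)C(=O)N(Cc2ccc(C(F)(F)F)cc2)C3=O)n1` gives < 5000 nM
compound 2 `COc1ccc(CN2C(=O)c3c(C)nc(-c4nc(C)no4)c(N)c3C2=O)cc1` gives < 5000 nM
compound 3 `Cc1noc(-c2nc(C)c3c(c2N)C(=O)N(Cc2ccccc2C(F)(F)F)C3=O)n1` gives < 5000 nM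

Each of these three values is a limit of the assay, not a number. Compound 3 therefore stands at that limit, as the other two do, so no ranking among them can be read. The measured steps a step that the two limits leave unreadable from compound 1 to compound 2, a step that the two limits leave unreadable from compound 1 to compound 3 and a step that the two limits leave unreadable from compound 2 to compound 3 are all unreadable for the same reason, as the limit of < 5000 nM in this assay, at which 3 of the 3 values shown sit, shows.

Compound 4 `Cc1noc(-c2nc(C)c3c(c2N)C(=O)N(Cc2ccc(N(C)C)cc2)C3=O)n1` differs from compound 3 by 4-(dimethylamino)phenyl in place of 2-(trifluoromethyl)phenyl on a saturated chain carbon bound to an amide-type nitrogen in a ring. Going by the values given here, no measured step bears readably on this change, so the expected size in this assay is unknown. The estimated step that the limit leaves unreadable from compound 3 to compound 4 is expected to stay small. Compound 4 is expected to give about 2500 nM, within 300 nM to 12000 nM.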

Compound 4, solubility: 7400 nM
Compound 4: middle estimate off by 3.0-fold (0.47 log units), on the low side; the range from low to high includes it.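

In this assay compound 4 gives 7400 nM, the first value shown here that is a number and not a limit of the assay. As far as these compounds go, with dimethylamino on the aromatic carbon, the steps are an at least 1.4-fold higher number from compound 3 to compound 4 (0.17 log units; that floor lies within the scatter), an at least 1.4-fold higher number from compound 2 to compound 4 (0.17 log units; that floor lies within the scatter) and an at least 1.4-fold higher number from compound 1 to compound 4 (0.17 log units; that floor lies within the scatter); these are floors, and the true sizes remain unknown. The steps among compound 1, compound 2 and compound 3 still cannot be read: the limit of < 5000 nM in this assay, at which 3 of the 4 values shown sit.

The compounds shown leave open how a morpholine or a carboxylic acid would read on that aromatic carbon in place of dimethylamino.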